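The source may hold more compounds than are shown below. What is called first, only, known or untested is meant among the compounds shown, and "the series" means these compounds.

Of the compounds shown here, two have been measured in an assay for binding affinity to 5-hydroxytryptamine receptor 1F (Homo sapiens), read by radioligand binding; on this read-out higher numbers stand for weaker inhibition and lower numbers for stronger inhibition. Compound 1 `CCCC(=O)Nc1ccc2[nH]cc(C3CCN(C)CC3)c2n1` gives 6.9 nM in this assay, and compound 2 `CN1CCC(c2c[nH]c3ccc(OS(C)(=O)=O)nc23)CC1` gives 4.7 nM. Of the two numbers that of compound 2 is the lower, but the step of a 1.5-fold lower number from compound 1 to compound 2 (0.17 log units; within the scatter) lies within the scatter, so the two compounds cannot be told apart on this evidence.

Compound 3 `CN1CCC(c2c[nH]c3ccc(OS(=O)(=O)c4ccc(F)cc4)nc23)CC1` differs from compound 2 by 4-fluorophenyl in place of methyl on a sulfonyl sulfur. For the measured compounds named here, the only measured step, a 1.5-fold lower number from compound 1 to compound 2 (0.17 log units; within the scatter), exchanges the whole group on the aromatic carbon rather than the group on the sulfonyl sulfur, and it was within the scatter; it therefore gives no direct guide to the present change. With nothing pointing to a shift of a particular size in this assay, the expectation for compound 3 is a number close to that of compound 2, with a wide range around it. For compound 3 the estimated value in this assay is 5 nM, with a range from 1.5 nM to 20 nM. This estimate corresponds to an expected step of a 1.1-fold higher number from compound 2 to compound 3 (0.03 log units; within the scatter).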

Compound 3, inhibition constant: 7.5 nM
Compound 3: middle estimate off by 1.5-fold (0.18 log units), on the low side; low and high end bracket the measured number.
By their numbers in this assay, from the lowest: compounds 2, 1 and 3 (each within the scatter of the next).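

In this assay, 4-fluorophenyl in place of methyl on a sulfonyl sulfur gives a 1.6-fold higher number from compound 2 to compound 3 (0.20 log units; within the scatter) and so makes no difference that can be told from the scatter, even though the entering group is much larger and brings an aromatic ring. For the compounds shown here, the earlier step exchanged the whole group on the aromatic carbon, whereas this one changes only the group on the sulfonyl sulfur, so it is the first direct reading of that place. Nothing measured here gives a reason for this result.

Still open, on these data alone, is whether a plain phenyl would read the same, which would show what the fluorine contributes on its own. Also open, as far as these compounds go, is whether a longer alkyl chain, or a phenyl ring carrying an amine or a carboxylic acid, would shift the number beyond the scatter.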